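Aryl swap on the amide of compound 1

The compounds below may be only part of what the source reports. "The series", "measured", "known", "first", "only" and "open" are said of these compounds alone.

Among the measured compounds shown here, compound 1 `CCN1CCN(c2cc(C)c3cc(NC(=O)c4ccc(Cl)cc4)ccc3n2)CC1` gives the lowest number of the three measured so far; in a functional assay on MCF7 cells (Homo sapiens) for antiproliferative activity, read by MTT assay, with a stated time of 72 h (a higher number here means a weaker inhibitor, a lower number a stronger inhibitor), compound 1 gives 1530 nM. The two other measured compounds carry a different amine on the shared core and a dichlorophenyl on the amide: compound 2 `Cc1cc(N(C)C)nc2ccc(NC(=O)c3ccc(Cl)c(Cl)c3)cc12` gives 33300 nM, and compound 3 `Cc1cc(N2CCCC2)nc2ccc(NC(=O)c3ccc(Cl)c(Cl)c3)cc12` gives 26300 nM, so both stand well beyond the scatter from compound 1. For the measured compounds named here, the single measured step, a 1.3-fold lower number from compound 2 to compound 3 (0.10 log units; within the scatter), concerns the amine and not the amide aryl, and lies within the scatter.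

Compound 4 `CCN1CCN(c2cc(C)c3cc(NC(=O)c4cccc(C)c4)ccc3n2)CC1` differs from compound 1 only at the amide: 3-methylphenyl in place of 4-chlorophenyl on a carbonyl carbon. Going by the values given here, no measured pair changes this aryl, so no measured step bears directly on it; the pairs with compound 2 and compound 3 alter two places at once and only show that the amide aryl region is not inert. On that basis a modest weakening is expected, with wide uncertainty, as a 2.0-fold higher number from compound 1 to compound 4 (0.29 log units; within the scatter). For compound 4 the expected value in this assay is estimated at 3000 nM, with a range from 1000 nM to 10000 nM.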

Compound 4, half-maximal inhibitory concentration: 7800 nM
Compound 4: middle estimate off by 2.6-fold (0.41 log units), on the low side; low and high end bracket the measured number.
By their numbers in this assay, from the lowest: compound 1; then compound 4; then compounds 3 and 2 (each within the scatter of the next).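

With the amine and the rest of the shared core unchanged, 3-methylphenyl in place of 4-chlorophenyl on the carbonyl carbon gives a 5.1-fold higher number from compound 1 to compound 4 (0.71 log units; beyond the scatter) in this assay, so the amide aryl can shift this read-out on its own, which the two-place differences involving compound 2 and compound 3 could not isolate. The leaving and entering groups match in heavy-atom count, in their single carbon-only aromatic ring, and in hydrogen-bond donor and acceptor counts, so the step arises without a change in any of these counted features. Nothing available on this pair gives a measured explanation for the step.

The step changes both the substituent and its place on the ring in one move, so the contributions of losing chlorine, gaining methyl and moving the substituent remain inseparable. Still open, on these data alone, are how a methoxy group, a nitrile or a carboxylic acid on this phenyl would read in this assay, and whether the step holds when dimethylamino or pyrrolidin-1-yl replaces the amine of compound 1.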